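From isopropyl to isobutyl on a sulfur

This account rests on a few compounds, and the source may have more. Where it says the series, first, only, none or still open, it means among the compounds named here.

In a functional assay on HepG2 cells (Homo sapiens) for cytotoxicity, read by MTT assay, with a stated time of 72 h (on this read-out lower numbers stand for stronger inhibition and higher numbers for weaker inhibition), compound 1 (`CCC[S+]([O-])CCCCN=C=S`) gives 3910 nM and compound 2 (`CC(C)[S+]([O-])CCCCN=C=S`) gives 2050 nM as its result. These two values lie within the usual scatter of each other, so compound 2 cannot be ranked against compound 1. Compound 3 (`CC(C)C[S+]([O-])CCCCN=C=S`) has not been measured yet. It carries isobutyl in place of isopropyl on a sulfur. Among the measured compounds shown here, only one measured step bears on this change: isopropyl in place of propyl on a sulfur gave a 1.9-fold lower number from compound 1 to compound 2 (0.28 log units; within the scatter) and that stayed within the scatter. With this single small step as the guide, no shift beyond the scatter is expected in this assay for the new change. The estimate amounts to a 1.2-fold higher number from compound 2 to compound 3 (0.09 log units; within the scatter) as an expected step inside the scatter. For compound 3 the expected value is 2500 nM with an estimated range from 1200 nM to 5000 nM as the likely span.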

Compound 3, half-maximal inhibitory concentration: 2160 nM
For compound 3 the middle estimate is 1.2-fold (0.06 log units) above the measured one; the range from low to high includes it.
By their numbers in this assay, from the lowest: compounds 2, 3 and 1 (each within the scatter of the next).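

In this assay, isobutyl in place of isopropyl on the sulfur gives a 1.1-fold higher number from compound 2 to compound 3 (0.02 log units; within the scatter) and stays within the scatter. The same holds for methyl in place of hydrogen on a saturated chain carbon bound to two saturated chain carbons, which gives a 1.8-fold lower number from compound 1 to compound 3 (0.26 log units; within the scatter) and is likewise within the scatter. This position on the sulfur has now carried propyl, isopropyl and isobutyl, and compound 1, compound 2 and compound 3 cannot be ranked against one another, so swapping among these small open carbon groups shows no readable effect here.

Going by these compounds, whether a longer chain such as octyl, a phenyl ring or an amine at this place would move the number beyond the scatter remains open. No measurement on hand offers an explanation for why these three groups read alike.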